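Amine-side swap on the shared core: compound 3 to compound 4

The source may hold more compounds than are shown below. What is called first, only, known or untested is meant among the compounds shown, and "the series" means these compounds.

Three compounds have numbers in a functional assay on HT-29 cells (Homo sapiens) for antiproliferative activity, read by MTT assay, with a stated time of 48 h; on this read-out higher numbers stand for weaker inhibition and lower numbers for stronger inhibition. Compound 1 `COc1cc(N/C=C\C(=O)c2cn(-c3ccccc3)nc2-c2ccccc2)cc(OC)c1OC` gives 9800 nM. Compound 2 `COc1ccc(-c2nn(-c3ccccc3)cc2C(=O)/C=C\Nc2ccc(C(F)(F)F)cc2)cc1` gives 9870 nM. Compound 3 `COc1ccc(-c2nn(-c3ccccc3)cc2C(=O)/C=C\Nc2ccc(O)cc2)cc1` gives 2460 nM, the lowest of the three, with both compound 1 and compound 2 sitting higher by steps beyond the scatter.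

Among the measured compounds shown here, the single step measured so far on this side of the molecule is a 4.0-fold lower number from compound 2 to compound 3 (0.60 log units; beyond the scatter). The next compound, compound 4 `COc1ccc(-c2nn(-c3ccccc3)cc2C(=O)/C=C\Nc2cc(OC)c(OC)c(OC)c2)cc1`, differs from compound 3 by 3,4,5-trimethoxyphenyl in place of 4-hydroxyphenyl on an amine nitrogen. For the measured compounds named here, no measured step covers this exchange directly. The only bearing is indirect: compound 1 carries the same 3,4,5-trimethoxyphenyl on the amine nitrogen but an unsubstituted phenyl on the core rather than the 4-methoxyphenyl of compound 3. In this assay compound 1 gives 9800 nM, while compound 3 gives 2460 nM. Going by the values given here, those two values differ in two places, so they set no step.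

The expectation for compound 4 is therefore a move back upward, short of the number shown by compound 1, estimated as a 2.4-fold higher number from compound 3 to compound 4 (0.39 log units; beyond the scatter). Compound 4 is expected to give 6000 nM in this assay, with a range from 2000 nM to 18000 nM.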

Compound 4, half-maximal inhibitory concentration: 14600 nM
Compound 4: the middle estimate sits 2.4-fold (0.39 log units) below what was measured; measured number inside the range.
By their numbers in this assay, from the lowest: compound 3; then compounds 1, 2 and 4 (each within the scatter of the next).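

Notes on the amine side: in this assay, the exchange on the amine nitrogen now has a direct reading, a 5.9-fold higher number from compound 3 to compound 4 (0.77 log units; beyond the scatter), so 4-hydroxyphenyl separates from 3,4,5-trimethoxyphenyl here as it already did from 4-(trifluoromethyl)phenyl. Among the compounds shown here, the other two groups do not separate from each other on this nitrogen, a 1.5-fold higher number from compound 2 to compound 4 (0.17 log units; within the scatter), which leaves compound 3 as the only one of the three compounds on this core that departs from the rest. With 3,4,5-trimethoxyphenyl held fixed, methoxy in place of hydrogen on an aromatic carbon also gives no separation, a 1.5-fold higher number from compound 1 to compound 4 (0.17 log units; within the scatter), and no other kind of measurement bears on these steps.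

Open, on these data alone, is whether the lower number of compound 3 belongs to the hydroxy group itself, a question that a 4-aminophenyl or 4-carboxyphenyl group on the same nitrogen would help to answer. Also open, as far as these compounds go, is whether 4-hydroxyphenyl on the amine nitrogen keeps its step on the core of compound 1, which carries an unsubstituted phenyl.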